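Chalcone-linked aryl amines: swapping the distal aryl group

The source may report more compounds than this note shows. Statements on the series, on what has been measured and on what is new or still open speak of the compounds shown alone.

Two compounds sharing one core have been examined in a functional assay on the whole organism (strain Kunming) for inhibition, with Mus musculus as the target, with a stated time of 1 h, at a dose of 40 mg/kg by the oral route; on this read-out higher numbers stand for more inhibition at the one dose given (going by the name of the read-out) and lower numbers for less inhibition. Compound 1 `O=C(/C=C/c1ccccc1)c1ccc(N2CCN(c3ccc(Cl)c(Cl)c3)CC2)cc1` gives 13.4%. Among the compounds with values here, compound 2 `O=C(/C=C/c1ccccc1)c1ccc(N2CCN(c3ccccc3F)CC2)cc1` gives 0.57%, which is the lowest of the two numbers; its only neighbour is compound 1, and the step of a number 12.8 percentage points lower from compound 1 to compound 2 (beyond the scatter) shows that replacing the aryl group on the amine nitrogen in the ring can shift the read-out by a modest amount, beyond the scatter.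

Compound 3 `Cc1ccc(N2CCN(c3ccc(C(=O)/C=C/c4ccccc4)cc3)CC2)c(C)c1` is not yet measured. It differs from compound 2 in one place: 2,4-dimethylphenyl in place of 2-fluorophenyl on an amine nitrogen in a ring. Within the data shown here, the one measured step that bears on this change is the aryl swap at the same position, a number 12.8 percentage points lower from compound 1 to compound 2 (beyond the scatter), which moved the number downward by a modest amount. Among the measured compounds shown here, no measured pair shows the effect of a 2,4-dimethylphenyl group, so the direction for compound 3 rests on that single comparison alone. Compound 3 is therefore expected to stay near the lower end of the range seen so far, with an estimated step of a number 7.4 percentage points higher from compound 2 to compound 3 (within the scatter) that is about at the edge of the scatter. The estimated value for compound 3 in this assay is 8%, expected to fall between 0% and 22%.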

Compound 3, a percentage reported as inhibition, in the whole organism at one dose (the size of the read-out at that dose, not a potency): 15%
Estimate against measurement, compound 3: 7 percentage points below, within the range that was stated.
By their numbers in this assay, from the lowest: compound 2; then compounds 1 and 3 (each within the scatter of the next).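

In this assay, the aryl group on the amine nitrogen in a ring now shows a step upward as well as one downward: the change to 2,4-dimethylphenyl gives a number 14.4 percentage points higher from compound 2 to compound 3 (beyond the scatter) and so shows that this position can move the number in both directions. Against 3,4-dichlorophenyl, the same group gives a number 1.6 percentage points higher from compound 1 to compound 3 (within the scatter), so two aryl groups with different substituents read alike, and among these three compounds only compound 2, with its 2-fluorophenyl group, stands apart. Nothing measured alongside these values bears on the reason for this difference, and the numbers alone do not explain it.

The compounds shown leave open whether the low number of compound 2 goes with the fluorine itself or with where the substituent sits on the aryl group, a question that a 2-chlorophenyl or a 2-methylphenyl group at this position would address. Also open, as far as these compounds go, is how a plain phenyl group, a methoxy group or a carboxylic acid on that aryl group would read at this single dose and time.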